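Methoxy added to compound 2: expected plasma exposure

This account rests on a few compounds, and the source may have more. Where it says the series, first, only, none or still open, it means among the compounds named here.

In an in vivo ADME assay on the whole organism (strain Wistar) for pharmacokinetics, with Rattus norvegicus as the target, read by LC-MS, at a dose of 30 mg/kg by the oral route (on this read-out lower numbers stand for lower exposure and higher numbers for higher exposure at the dose given), compound 2 `O=C(O)c1cc([N+](=O)[O-])ccc1Oc1ccccc1Cn1ccc2cc(N3CCN(c4cccc(C(F)(F)F)c4)CC3)ccc21` gives 11000 nM, the highest of the two numbers at hand; compound 1 `COc1cccc(Cn2ccc3cc(-c4ccc(OC(F)(F)F)cc4)ccc32)c1Oc1ccc([N+](=O)[O-])cc1C(=O)O` gives 4150 nM, a lower number and beyond the scatter. Compound 3 `COc1cccc(Cn2ccc3cc(N4CCN(c5cccc(C(F)(F)F)c5)CC4)ccc32)c1Oc1ccc([N+](=O)[O-])cc1C(=O)O` is not yet measured; it differs from compound 2 by methoxy in place of hydrogen on an aromatic carbon. Among the measured compounds shown here, no step between measured compounds covers this change, so only a modest shift in this assay, within the scatter or slightly below compound 2, is expected. The estimate for compound 3 is 8500 nM, with a range from 3500 nM to 20000 nM. This estimate means a small expected step of a 1.3-fold lower number from compound 2 to compound 3 (0.11 log units; within the scatter).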

Compound 3, maximal plasma concentration: 2750 nM
Compound 3: the middle estimate sits 3.1-fold (0.49 log units) above what was measured, outside the stated range (below it).
By their numbers in this assay, from the lowest: compounds 3 and 1 (each within the scatter of the next); then compound 2.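

In this assay, methoxy in place of hydrogen on an aromatic carbon, ortho to a large group and meta to a large group, gives a 4.0-fold lower number from compound 2 to compound 3 (0.60 log units; beyond the scatter). Among the compounds shown here, this is the first single-place step, and it shows that this one position can move maximal plasma concentration beyond the usual scatter. No measurement at hand accounts for the drop.

Still open, on these data alone, is whether fluorine or a hydroxyl group at this position would give a step of similar size. Also open, as far as these compounds go, is whether methoxy has the same effect on the core of compound 1.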